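The source may report more compounds than this note shows. Statements on the series, on what has been measured and on what is new or still open speak of the compounds shown alone.

Measured compounds:
compound 1 `CNS(=O)(=O)Cc1noc2ccccc12` with 23 mg/kg
compound 2 `CCNS(=O)(=O)Cc1noc2ccccc12` with 39 mg/kg
compound 3 `CCNS(=O)(=O)Cc1noc2ccc(Cl)cc12` with 21 mg/kg

All three were run in a functional assay on the whole organism (strain STD-dd) with Mus musculus as the target, in the maximal electroshock model, with a stated time of 2 h; on this read-out lower numbers stand for an effect already at smaller amounts and higher numbers for an effect only at larger amounts of compound. The values sit close together: the step of a 1.7-fold higher number from compound 1 to compound 2 (0.23 log units; within the scatter) and the step of a 1.9-fold lower number from compound 2 to compound 3 (0.27 log units; within the scatter) are each inside the usual scatter, so no order among compounds 1, 2 and 3 can be read from these numbers. Compound 1 and compound 3 share no single counted difference; the difference between their two cores is not broken down here.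

Among the compounds with values here, the one change that appears twice in the set is the growth of the chain on the sulfonamide nitrogen. From compound 1 to compound 2 it reads methyl in place of hydrogen on a saturated chain carbon bound to a sulfonamide nitrogen and its measured size is a 1.7-fold higher number from compound 1 to compound 2 (0.23 log units; within the scatter). The unmeasured compound 4 `CC(C)NS(=O)(=O)Cc1noc2ccc(Cl)cc12` arises from compound 3 by methyl in place of hydrogen on a saturated chain carbon bound to a saturated chain carbon and a sulfonamide nitrogen. This is the same kind of change, not the same one: in the first case the place is on a saturated chain carbon bound to a sulfonamide nitrogen, in the second on a saturated chain carbon bound to a saturated chain carbon and a sulfonamide nitrogen.

Because the earlier instance gave a 1.7-fold higher number from compound 1 to compound 2 (0.23 log units; within the scatter), the step of a 1.5-fold higher number from compound 3 to compound 4 (0.18 log units; within the scatter) is expected to be of similar small size, a slightly higher number. Compound 4 is therefore estimated in this assay at 32 mg/kg, with a range from 15 mg/kg to 70 mg/kg, resting on compound 3 with 21 mg/kg as the starting point.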

Compound 4, dose for half-maximal effect: 100 mg/kg
The estimate for compound 4 lay 3.1-fold (0.49 log units) below the measured number; measured number outside the range, above it.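

In this assay, within the data shown here, the ethyl to isopropyl change gives a 4.8-fold higher number from compound 3 to compound 4 (0.68 log units; beyond the scatter) and is the only step that is read as beyond the scatter. Set beside the earlier methyl step, its size shows that the step measured on one core did not carry over in size to the other: the same change on two cores in this assay, a 1.7-fold higher number (0.23 log units; within the scatter) from compound 1 to compound 2 and a 4.8-fold higher number (0.68 log units; beyond the scatter) from compound 3 to compound 4, 2.8-fold (0.45 log units) apart, beyond the scatter of two such steps. This does not show whether the gap belongs to the core or to the place of the new methyl, since the two instances differ in both, and each rests on a single pair; nor does it establish a shared direction, as the first step lies within the scatter and only the second can be read as a real rise, so no general rule for growing this chain follows from them.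

Still open, on these data alone, is how an isopropyl on the sulfonamide nitrogen reads on the core of compound 1 and how a methyl there reads on the core of compound 3, two pairs that would separate the effect of the chloro from that of the place. Also open, as far as these compounds go, is how a longer chain such as n-propyl or a ring such as cyclopropyl on that nitrogen fits beside compound 4.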